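The compounds below may be only part of what the source reports. "The series", "measured", "known", "first", "only" and "open" are said of these compounds alone.

In a functional assay on MCF7 cells (Homo sapiens) for antiproliferative activity, read by MTT assay, with a stated time of 72 h (on this read-out higher numbers stand for weaker inhibition and lower numbers for stronger inhibition), compound 1 (`CCCSc1nc(N/N=C/c2ccc(N(C)C)cc2)c2nnn(Cc3ccccc3)c2n1`) gives 12200 nM and compound 2 (`CCCSc1nc(N/N=C/c2c(O)ccc3ccccc23)c2nnn(Cc3ccccc3)c2n1`) gives 6400 nM, so compound 2 stands within the scatter of compound 1. Compound 3 (`CCCSc1nc(N/N=C/c2ccccc2F)c2nnn(Cc3ccccc3)c2n1`) has 2-fluorophenyl in place of 2-hydroxynaphthalen-1-yl on a carbon with a double bond to nitrogen. Among the measured compounds shown here, the only measured change at this carbon is a 1.9-fold lower number from compound 1 to compound 2 (0.28 log units; within the scatter), and it involves neither the entering group nor any fluorine. No shift beyond the scatter is therefore expected in this assay. The estimated step is a 1.4-fold higher number from compound 2 to compound 3 (0.15 log units; within the scatter). Compound 3 is expected at 9000 nM, with an estimated range of 3500 nM to 25000 nM.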

Compound 3, half-maximal inhibitory concentration: > 64000 nM
Compound 3 gave a limit, no number; the forecaster's own chance of this, stated with the estimate: 8%; middle value at least 7.1-fold (0.85 log units) away from the limit.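

The group on this carbon is not interchangeable: in this assay, 2-fluorophenyl in place of 2-hydroxynaphthalen-1-yl gives an at least 10-fold higher number from compound 2 to compound 3 (1.00 log units; beyond the scatter), and 2-fluorophenyl in place of 4-(dimethylamino)phenyl gives an at least 5.2-fold higher number from compound 1 to compound 3 (0.71 log units; beyond the scatter). Among the compounds shown here, the only earlier step at this carbon, a 1.9-fold lower number from compound 1 to compound 2 (0.28 log units; within the scatter), gave no sign of this. Compound 3 gives a limit, not a number: the limit of > 64000 nM in this assay, at which 1 of the 3 values shown sits.

Open, on these data alone, is whether the fluorine itself goes with the weaker result, or the other differences from compound 2. An unsubstituted phenyl or a 2-hydroxyphenyl on this carbon would separate these.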